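Regioisomeric Pyrimidinyl Swap and Its Expected Cytotoxicity

This account rests on a few compounds, and the source may have more. Where it says the series, first, only, none or still open, it means among the compounds named here.

In an ADME assay on HepG2 cells (Homo sapiens) for cytotoxicity, read by neutral red uptake, with a stated time of 48 h (on this read-out higher numbers stand for weaker inhibition and lower numbers for stronger inhibition), compound 1 `Cc1cc(NCCCCCCNc2ccnc3cc(Cl)ccc23)nc(N2CCN(C)CC2)n1` gives 6300 nM. Compound 2 `Cc1cc(Cl)nc(NCCNc2ccnc3cc(Cl)ccc23)n1` gives 43000 nM in this assay. Compound 3 `Cc1cc(Cl)nc(NCCCCCCNc2ccnc3cc(Cl)ccc23)n1` gives 8100 nM in this assay, the second highest of the three numbers: its gap to compound 1 lies within the scatter, whereas compound 2 stands beyond it with a higher number. Compound 4 `Cc1cc(NCCCCCCNc2ccnc3cc(Cl)ccc23)nc(Cl)n1` has not yet been measured. It differs from compound 3 in one place: 2-chloro-6-methylpyrimidin-4-yl in place of 4-chloro-6-methylpyrimidin-2-yl on an amine nitrogen. The two have the same atoms joined differently, and no step beyond the scatter is expected in this assay. The expected step of a 1.0-fold lower number from compound 3 to compound 4 (0.01 log units; within the scatter) is thus estimated to stay inside the scatter. Compound 4 is expected to give 8000 nM (range 3000 nM to 22000 nM).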

Compound 4, half-maximal inhibitory concentration: 9100 nM
For compound 4 the middle estimate is 1.1-fold (0.06 log units) below the measured one, within the range that was stated.
By their numbers in this assay, from the lowest: compounds 1, 3 and 4 (each within the scatter of the next); then compound 2.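

In this assay the regioisomeric swap, 2-chloro-6-methylpyrimidin-4-yl in place of 4-chloro-6-methylpyrimidin-2-yl on an amine nitrogen, comes to a 1.1-fold higher number from compound 3 to compound 4 (0.05 log units; within the scatter), so on the saturated chain these two attachments of the pyrimidine read alike. Chloro in place of 4-methylpiperazin-1-yl on an aromatic carbon comes to a 1.4-fold higher number from compound 1 to compound 4 (0.16 log units; within the scatter), so that exchange does not separate the compounds either. Nothing available explains these results.

Going by these compounds, whether a morpholin-4-yl or methoxy group on that carbon would read alike remains open. So does whether the swap would hold on the shorter chain of compound 2.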